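The source may report more compounds than this note shows. Statements on the series, on what has been measured and on what is new or still open speak of the compounds shown alone.

Measured so far in a functional assay on cells (Cancer cell lines, Homo sapiens) for inhibition; on this read-out lower numbers stand for stronger inhibition of growth and higher numbers for weaker inhibition of growth:
- compound 1 `Cc1cn2c(/C=N/NC(=N)N)c(-c3ccsc3)nc2s1`: 28200 nM
- compound 2 `N=C(N)N/N=C/c1c(-c2cc(Cl)sc2Cl)nc2n1CCS2`: 20000 nM
- compound 3 `N=C(N)N/N=C/c1c(-c2ccsc2)nc2sccn12`: 29500 nM

All three values lie within the scatter of one another, so compound 3 stands level with compound 1 and compound 2, and no order can be read among them in this assay.

The next compound is compound 4 `Cc1cc(-c2nc3sccn3c2/C=N/NC(=N)N)c(C)s1`, with 2,5-dimethylthiophen-3-yl in place of thiophen-3-yl on an aromatic carbon of the shared core: 2,5-dimethylthiophen-3-yl in place of thiophen-3-yl on an aromatic carbon.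

Among the measured compounds shown here, one measured step bears on this, and only indirectly. It is hydrogen in place of methyl on an aromatic carbon, a 1.0-fold higher number from compound 1 to compound 3 (0.02 log units; within the scatter), and it lies within the scatter. That change sits on the shared core and not on the thiophen-3-yl group. For the measured compounds named here, compound 2 differs from compound 3 in more than one place, so it gives no clean step. Going by the values given here, no measured step shows a change on the thiophen-3-yl group itself, so the size of the effect there is unknown.

No step beyond the scatter is therefore expected, and the estimated change is a 1.2-fold lower number from compound 3 to compound 4 (0.09 log units; within the scatter). For compound 4 the expected value is 24000 nM, with an estimated range of 11000 nM to 50000 nM.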

Compound 4, concentration for total growth inhibition: 32400 nM
Compound 4: the middle estimate sits 1.4-fold (0.13 log units) below what was measured; measured number inside the range.
By their numbers in this assay, from the lowest: compounds 2, 1, 3 and 4 (each within the scatter of the next).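

In this assay, among the compounds shown here, a 1.1-fold higher number from compound 3 to compound 4 (0.04 log units; within the scatter) gives the first reading of a change on the thiophen-3-yl group itself, the group on an aromatic carbon of the five-membered aromatic ring with 2 nitrogen. The position therefore accepts 2,5-dimethylthiophen-3-yl, with 7 heavy atoms in place of 5, without a shift beyond the scatter, whereas the earlier single step concerned only a methyl group on the shared core. No information is available to explain this result.

This one step covers a single replacement and cannot show whether the ring as a whole is free to vary, so the reach of the finding stays limited to compound 3 and compound 4. Open is whether a different kind of group at this place, such as an amine, a carboxylic acid or a longer alkyl chain on the thiophene ring, would move the number in this assay beyond the scatter, as no step shown so far does so at any position.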